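Moving the fluorine on the N-aryl ring: compound 3 to compound 4

The source may hold more compounds than are shown below. What is called first, only, known or untested is meant among the compounds shown, and "the series" means these compounds.

In a physicochemical assay for solubility, read by turbidimetry, measured as kinetic solubility, at pH 7.4 (on this read-out lower numbers stand for lower solubility and higher numbers for higher solubility), compound 1 `CC1SC(c2cccc(C(=O)NCCCCc3ccccc3)c2)N(c2ccc(C3CC3)cc2)C1=O` gives 2000 nM, compound 2 `O=C(NCCCCn1cccn1)c1cccc(C2SCC(=O)N2c2ccccn2)c1` gives 50000 nM, and compound 3 `O=C(NCCCCc1ccccc1)c1cccc(C2SCC(=O)N2c2cccc(F)c2)c1` gives 10000 nM. On these three numbers compound 3 stands second highest: above compound 1 and below compound 2, both gaps beyond the scatter. Compound 4 `O=C(NCCCCc1ccccc1)c1cccc(C2SCC(=O)N2c2ccccc2F)c1` is not yet measured. It differs from compound 3 in one place: 2-fluorophenyl in place of 3-fluorophenyl on an amide-type nitrogen in a ring. Among the compounds with values here, no measured pair in this set shows a change of this kind, so the size of the step is uncertain. With the same atoms joined differently and no change in donors, acceptors or charge, a step of no more than the scatter is expected, with no clear direction. Compound 4 is estimated at 12000 nM (range 4000 nM to 35000 nM), which means an expected step of a 1.2-fold higher number from compound 3 to compound 4 (0.08 log units; within the scatter).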

Compound 4, solubility: 10000 nM
Beside the measured number, compound 4's estimate is 1.2-fold (0.08 log units) above it; the range from low to high includes it.
By their numbers in this assay, from the lowest: compound 1; then compounds 3 and 4 (each within the scatter of the next); then compound 2.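

In this assay, within the data shown here, 2-fluorophenyl in place of 3-fluorophenyl on the amide-type nitrogen gives no change at the digits printed from compound 3 to compound 4 (within the scatter), the only one-place step so far. For this pair, then, moving the fluorine on this ring does not separate the two compounds in this read-out. No supporting data bear on this result.

Still open, on these data alone, is whether an amine or a carboxylic acid on this ring would shift the reading. Also open, as far as these compounds go, is whether the same fluorine move would read alike with a different amide side chain.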